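Methoxy to Trifluoromethyl on a Benzoxazole Piperazine

The source may hold more compounds than are shown below. What is called first, only, known or untested is meant among the compounds shown, and "the series" means these compounds.

Measured compounds:
compound 1, `CC(C)c1cccc2nc(N3CCN(C)CC3)oc12`: < 4
compound 2, `COc1ccc2oc(N3CCN(C)CC3)nc2c1`: 4.78

For the measured compounds named here, in a functional assay on ileum (strain Hartley) for agonist activity at 5-hydroxytryptamine receptor 3A (Cavia porcellus) (on this read-out higher numbers stand for higher potency (the scale is a negative logarithm) and lower numbers for lower potency), compound 2 gives 4.78, the only number recorded. For compound 1 the value of < 4 is a limit of the assay and not a number, as the limit of < 4 in this assay, at which 1 of the 2 values shown sits, records. Compound 3, `CN1CCN(c2nc3cc(C(F)(F)F)ccc3o2)CC1`, has not yet been measured; it differs from compound 2 by trifluoromethyl in place of methoxy on an aromatic carbon. Going by the values given here, no measured step exists between these two, so the effect of this change is unknown. The step of a number 0.02 log units higher from compound 2 to compound 3 (within the scatter) is expected to stay within the usual scatter. Compound 3 is estimated at 4.8, between 4.2 and 5.4.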

Compound 3, negative logarithm of the half-maximal effective concentration: < 4
Compound 3 ended at the assay's limit; the forecaster's own chance of this, stated with the estimate: 20%; middle value at least 0.80 log units away from the limit.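

For the compounds shown here, this is the first step read at this position: in this assay, trifluoromethyl in place of methoxy on this aromatic carbon gives a number at least 0.78 log units lower from compound 2 to compound 3 (beyond the scatter). The position is therefore not indifferent to the group it carries, since methoxy here gives a measurable response and trifluoromethyl does not. Compound 3 gives < 4, which is a limit of the assay and not a number, and the limit now holds for most of the series: the limit of < 4 in this assay, at which 2 of the 3 values shown sit.

The compounds shown leave open how far past the limit compound 3 lies, and so the full size of the step. They also leave open how an amine or a chlorine atom on the same aromatic carbon would read.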